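The source may hold more compounds than are shown below. What is called first, only, known or untested is meant among the compounds shown, and "the series" means these compounds.

Three measured members share one core and differ only in the group on an aromatic carbon of the ring bearing the trifluoromethyl group: compound 1 `CC(C(=O)NCc1ccc(C(F)(F)F)cc1N1CCCC1)c1ccc(NS(C)(=O)=O)c(F)c1`, compound 2 `CC(C(=O)NCc1ccc(C(F)(F)F)cc1OC1CCCC1)c1ccc(NS(C)(=O)=O)c(F)c1` and compound 3 `CC(C(=O)NCc1ccc(C(F)(F)F)cc1OC1CCCCC1)c1ccc(NS(C)(=O)=O)c(F)c1`. In an assay on CHO cells for antagonist activity at transient receptor potential cation channel subfamily V member 1 (Homo sapiens), read by FLIPR (on this read-out higher numbers stand for weaker inhibition and lower numbers for stronger inhibition), compound 1 gives 2.3 nM, compound 2 gives 0.6 nM and compound 3 gives 0.7 nM. Compound 3 holds the second highest of the three numbers; it sits within the scatter of compound 2, since a 1.2-fold higher number from compound 2 to compound 3 (0.07 log units; within the scatter), and well apart from compound 1, since a 3.3-fold lower number from compound 1 to compound 3 (0.52 log units; beyond the scatter). The other recorded step is a 3.8-fold lower number from compound 1 to compound 2 (0.58 log units; beyond the scatter).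

Compound 4 `CCCCSc1cc(C(F)(F)F)ccc1CNC(=O)C(C)c1ccc(NS(C)(=O)=O)c(F)c1` is next: butylsulfanyl in place of cyclohexyloxy on an aromatic carbon. None of the recorded steps replaces an oxygen-linked ring by a sulfur-linked chain, so their bearing is indirect. The two steps from compound 1 are modest, and the ring-size step is within the scatter; a change of at most similar size is therefore expected. For compound 4 the expected value in this assay is 1.5 nM, within a range from 0.5 nM to 5 nM. This estimate corresponds to an expected 2.1-fold higher number from compound 3 to compound 4 (0.33 log units; beyond the scatter).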

Compound 4, inhibition constant: 1.9 nM
Estimate against measurement, compound 4: 1.3-fold (0.10 log units) below; the range from low to high includes it.
By their numbers in this assay, from the lowest: compounds 2 and 3 (each within the scatter of the next); then compounds 4 and 1 (each within the scatter of the next).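

In this assay, this position takes an open butylsulfanyl chain in place of a ring, but the chain gives up ground against both oxygen-linked rings (a 2.7-fold higher number from compound 3 to compound 4 (0.43 log units; beyond the scatter)) and (a 3.2-fold higher number from compound 2 to compound 4 (0.50 log units; beyond the scatter)). Against the nitrogen-linked pyrrolidin-1-yl group there is no separation (a 1.2-fold lower number from compound 1 to compound 4 (0.08 log units; within the scatter)), so a sulfur-linked chain and a nitrogen-linked ring cannot be told apart here, and only the cyclopentyloxy and cyclohexyloxy groups stand apart from both. No measurement is at hand that accounts for these differences.

On these data alone, the step to compound 4 changes the linking atom and replaces the ring with a chain in one move, so the share of each remains open. As far as these compounds go, a butoxy chain or a cyclohexylsulfanyl group at this place would separate the two, and longer or branched sulfur-linked chains remain open as well.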